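Bromo Added to the Methoxyphenyl Amide: Cytotoxicity Outlook

The compounds below may be only part of what the source reports. "The series", "measured", "known", "first", "only" and "open" are said of these compounds alone.

Measured so far:
compound 1, `O=C(Nc1ccc(Sc2nc3ccccc3s2)cc1)c1cccc(Br)c1`: 74000 nM
compound 2, `COc1ccccc1C(=O)Nc1ccc(Sc2nc3ccccc3s2)cc1`: > 100000 nM

In an ADME assay on HEK293 cells (Homo sapiens) for cytotoxicity, read by reporter gene assay and resazurin assay, with a stated time of 48 h (on this read-out higher numbers stand for lower toxicity in this test and lower numbers for higher toxicity in this test), compound 1 gives 74000 nM as a number. Compound 2 gives > 100000 nM, which is a limit of this assay and not a number. Within the data shown here, the one measured step, an at least 1.3-fold higher number from compound 1 to compound 2 (0.13 log units; that floor lies within the scatter), is bounded by the limit of > 100000 nM in this assay, at which 1 of the 2 values shown sits, and tells nothing about direction beyond the scatter.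

Compound 3, `COc1c(Br)cccc1C(=O)Nc1ccc(Sc2nc3ccccc3s2)cc1`, differs from compound 2 by bromo in place of hydrogen on an aromatic carbon. Among the measured compounds shown here, no measured step concerns bromo entering in place of hydrogen; the step from compound 1 to compound 2 exchanges whole aryl groups, so it bears on the new step only loosely, and compound 1, which carries a bromo on its own aryl group, still gives a number rather than a limit.

Compound 3 is therefore expected to sit near compound 2 with a step of a number no higher from compound 2 to compound 3 (the limit leaves the size open), within the scatter. Compound 3 is estimated at 100000 nM, ranging from 50000 nM to 200000 nM.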

Compound 3, half-maximal cytotoxic concentration: > 100000 nM
Compound 3 was reported as a limit; the forecaster's own chance of this, stated with the estimate: 50%; the middle value lies on the limit itself.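

In this assay compound 3, with bromo ortho to a methoxy group, still gives > 100000 nM, a limit of the assay and not a number, so bromo at this position brings no number into view. The step for this bromo cannot be read, since both of its ends are limits: the limit of > 100000 nM in this assay, at which 2 of the 3 values shown sit. Methoxy in place of hydrogen on the aryl group of the bromo compound gives an at least 1.3-fold higher number from compound 1 to compound 3 (0.13 log units; that floor lies within the scatter), a comparison of a single change that still shows no direction beyond the scatter.

From the compounds shown here alone, how far compound 2 and compound 3 lie past the limit stays open. Also open, going by these compounds, is whether an amine or a carboxylic acid in place of the bromo would give a number in this assay at all.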